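Swapping a nitro group for bromine on a phenol

A few compounds are considered here, and "the series" means these few. Any claim that something is new, unique, unknown or untested is made for them only; others in the source may bear on it.

Of the compounds shown here, three built on one shared core have been tested in a functional assay on KB cells (Homo sapiens) for antiproliferative activity, read by MTT assay, with a stated time of 48 h; a higher number here means a weaker inhibitor, a lower number a stronger inhibitor. Compound 1 `CN(C)C(=O)N(Cc1cccc([N+](=O)[O-])c1)Cc1ccco1` gives 23800 nM. Compound 2 `CN(C)C(=O)N(Cc1ccco1)Cc1cc(Cl)ccc1O` gives 49500 nM. Compound 3 `CN(C)C(=O)N(Cc1ccco1)Cc1cc([N+](=O)[O-])ccc1O` gives 20800 nM, the smallest of the three numbers, although its gap to compound 1 is within the scatter, as the step of a 1.1-fold lower number from compound 1 to compound 3 (0.06 log units; within the scatter) shows. The step of a 2.4-fold lower number from compound 2 to compound 3 (0.38 log units; beyond the scatter) is the only one beyond the scatter, and it was modest.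

Compound 4 `CN(C)C(=O)N(Cc1ccco1)Cc1cc(Br)ccc1O` differs from compound 3 in one place: bromo in place of nitro on an aromatic carbon. Among the compounds with values here, no measured step exchanges nitro for bromo directly. The nearest guide is a 2.4-fold lower number from compound 2 to compound 3 (0.38 log units; beyond the scatter), where chloro gave way to nitro; going back from nitro to a halogen, here bromo, would be expected to undo roughly that modest change and raise the number in this assay. The step of a 1.1-fold lower number from compound 1 to compound 3 (0.06 log units; within the scatter) adds that the hydroxy group left the number within the scatter. Compound 4 is therefore expected to give about 45000 nM in this assay, with a likely range from 20000 nM to 100000 nM. That would mean an expected step of a 2.2-fold higher number from compound 3 to compound 4 (0.34 log units; beyond the scatter).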

Compound 4, half-maximal inhibitory concentration: 32800 nM
Estimate against measurement, compound 4: 1.4-fold (0.14 log units) above, and the stated range covers the measured number.
By their numbers in this assay, from the lowest: compounds 3, 1, 4 and 2 (each within the scatter of the next, the first and the last beyond it).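

In this assay, bromo at this place, para to a hydroxy group, cannot be told apart from either of the two groups already tested there: the step from nitro is a 1.6-fold higher number from compound 3 to compound 4 (0.20 log units; within the scatter), and the step from chloro is a 1.5-fold lower number from compound 2 to compound 4 (0.18 log units; within the scatter). Within the data shown here, the earlier compounds offered only one clear step at this place, a 2.4-fold lower number from compound 2 to compound 3 (0.38 log units; beyond the scatter), which made nitro and chloro look like two separate levels, but bromo now sits within the scatter of both, so the three groups do not fall into two clear sets and the modest gap between the two ends is all that remains to read. Nothing measured here bears on why these groups give the numbers they do.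

The compounds shown leave open whether a quite different group at this same place, such as an amine or a carboxylic acid, would give a number beyond the scatter of these three. They also leave open whether a longer chain at this place would shift the number any further than the halogens and nitro do.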